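The source may hold more compounds than are shown below. What is called first, only, known or untested is meant among the compounds shown, and "the series" means these compounds.

Of the compounds shown here, two built on the shared core have been tested in a functional assay on HeLa cells (Homo sapiens) for cytotoxicity; on this read-out higher numbers stand for weaker inhibition and lower numbers for stronger inhibition. Compound 1 `C=C1C(=O)O[C@]2(C)CC[C@@H]1C[C@H](O)[C@@]1(C)CC[C@H](O1)[C@](C)(O)CC[C@H]2O` gives > 20 ug/mL, which is a limit of the assay and not a number. Compound 2 `C=C1C(=O)O[C@]2(C)CC[C@@H]1C[C@H](O)[C@@]1(C)CC[C@H](O1)[C@](C)(O)CCC2=O` gives > 20 ug/mL, which is also a limit. Compound 2 therefore stands at the limit of > 20 ug/mL in this assay, at which 2 of the 2 values shown sit, and no measured number is available for it. Compound 3 `C=C1C(=O)O[C@]2(C)CC[C@@H]1C[C@H](OC(C)=O)[C@@]1(C)CC[C@H](O1)[C@](C)(O)CCC2=O` differs from compound 2 in one place: acetyl in place of hydrogen on an oxygen on a saturated carbon, or hydroxy to acetoxy. In this assay, a small gain in inhibition is expected, though the result could again be only a limit. An estimated step of an at least 1.1-fold lower number from compound 2 to compound 3 (0.04 log units; that floor lies within the scatter) is expected, towards lower numbers and not far beyond the scatter. For compound 3, the estimated value is 18 ug/mL, with an expected range from 6 ug/mL to 40 ug/mL.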

Compound 3, half-maximal inhibitory concentration: > 20 ug/mL
Compound 3 was reported as a limit (the forecaster's own chance of this, stated with the estimate: 55%); middle value at least 1.1-fold (0.04 log units) from the limit.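

Compound 2 and compound 3 both stand at a limit in this assay, so the step between them cannot be read: the limit of > 20 ug/mL in this assay, at which 3 of the 3 values shown sit.

The compounds shown leave open whether hydroxy to acetoxy changes the read-out at all, and whether any of them has a measurable value in this assay.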